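Acetoxy for trifluoromethyl on the aryl of compound 2

A few compounds are considered here, and "the series" means these few. Any claim that something is new, unique, unknown or untested is made for them only; others in the source may bear on it.

Compound 2 `CCOC(=O)c1nn(-c2ccc(C(F)(F)F)cc2)c(=O)c2c(N)scc12` holds the higher of the two numbers in hand: in an assay on CHO-K1 cells for displacement of a labelled ligand from adenosine receptor A1 (Homo sapiens), tested at 50 uM (a higher number here means more inhibition at the concentration tested (going by the name of the read-out), a lower number less inhibition), compound 2 gives 77.2%. Within the data shown here, its only neighbour, compound 1 `Cc1sc(N)c(C(=O)c2cccs2)c1C`, gives in this assay 50.3%, a gap beyond the scatter. Compound 3 `CCOC(=O)c1nn(-c2ccc(OC(C)=O)cc2)c(=O)c2c(N)scc12` is not yet measured. It differs from compound 2 by acetoxy in place of trifluoromethyl on an aromatic carbon. Among the measured compounds shown here, no measured pair shows this exchange, so its size is open. A modest drop is expected, estimated as a number 12.2 percentage points lower from compound 2 to compound 3 (beyond the scatter), though a result within the scatter would not surprise. Compound 3 is expected to give 65% in this assay, with a range from 40% to 85%.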

Compound 3, a percentage reported as inhibition, at one concentration (the size of the read-out at that concentration, not a potency): 48.9%
For compound 3 the middle estimate is 16.1 percentage points above the measured one; measured number inside the range.
By their numbers in this assay, from the lowest: compounds 3 and 1 (each within the scatter of the next); then compound 2.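

Placed para to a large group on the aromatic ring, the exchange of trifluoromethyl for acetoxy gives in this assay a number 28.3 percentage points lower from compound 2 to compound 3 (beyond the scatter), so this position responds to the group it carries. Each group holds 4 heavy atoms, so the step does not come with a change in heavy-atom count, while acetoxy adds 2 hydrogen-bond acceptors. Nothing available accounts for the step.

Open, going by these compounds, is whether an amine, a carboxylic acid or a plain methoxy group here would stay near compound 2 or near compound 3. A single pair also leaves open whether the step carries over to other cores.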